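Aryl for methyl on the ring amine nitrogen

The source may report more compounds than this note shows. Statements on the series, on what has been measured and on what is new or still open speak of the compounds shown alone.

Compound 2 `CCCn1c(=O)[nH]c2nc(-c3ccc(S(=O)(=O)N4CCN(C)CC4)cc3)[nH]c2c1=O` gives the lowest of the three numbers in an assay on CHO cells for displacement of a labelled ligand from adenosine receptor A3 (Homo sapiens), read by scintillation counting, with a stated time of 45 min, tested at 1 uM, in the presence of a further agent that is not named here (on this read-out higher numbers stand for more inhibition at the one concentration tested (going by the name of the read-out) and lower numbers for less inhibition), namely 7%. Compound 3 `CCCn1c(=O)[nH]c2nc(-c3ccc(S(=O)(=O)N4CCN(Cc5ccc(Br)cc5)CC4)cc3)[nH]c2c1=O` gives 28%, and compound 1 `CCCn1c(=O)c2[nH]c(-c3ccc(S(=O)(=O)N4CCN(c5ccc(Cl)cc5)CC4)cc3)nc2n(CC)c1=O`, which carries an aryl group directly on the same ring nitrogen within a differently substituted core, gives 28%. Compound 4 `CCCn1c(=O)[nH]c2nc(-c3ccc(S(=O)(=O)N4CCN(c5cccc(F)c5)CC4)cc3)[nH]c2c1=O` differs from compound 2 by 3-fluorophenyl in place of methyl on an amine nitrogen in a ring. Within the data shown here, the one relevant measured step, a number 21 percentage points higher from compound 2 to compound 3 (beyond the scatter), also replaces a small substituent at that nitrogen with a halogenated phenyl ring, and the value of compound 1 points the same way. Compound 4 is therefore expected to show a modest rise, a number 18 percentage points higher from compound 2 to compound 4 (beyond the scatter), rather than none. The estimated inhibition of compound 4 is 25%, within a range from 8% to 45%.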

Compound 4, a percentage reported as inhibition, at one concentration (the size of the read-out at that concentration, not a potency): 44%
For compound 4 the middle estimate is 19 percentage points below the measured one; low and high end bracket the measured number.
By their numbers in this assay, from the lowest: compound 2; then compounds 1 and 3 (each within the scatter of the next); then compound 4.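

In this assay, the 3-fluorophenyl group on this ring nitrogen gives the largest step seen so far, a number 37 percentage points higher from compound 2 to compound 4 (beyond the scatter), against a number 21 percentage points higher from compound 2 to compound 3 (beyond the scatter) for the 4-bromobenzyl group. The direct comparison, a number 16 percentage points higher from compound 3 to compound 4 (beyond the scatter), shows that a large group at this nitrogen need not stop at the level of the benzyl compound. Nothing given here bears on why the number rises.

On these data alone, how an unsubstituted phenyl or a 4-fluorophenyl group would compare at this nitrogen remains open. So does whether the gain follows the fluorine or the aryl ring bound directly to the nitrogen.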